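A few compounds are considered here, and "the series" means these few. Any claim that something is new, unique, unknown or untested is made for them only; others in the source may bear on it.

Compound 3 `COC(=O)C1=C(C)N=C(C)/C(=C(\O)OC)C1c1ccccc1I` sits second highest of the three numbers in a functional assay (muscle tissue) with Cavia porcellus as the target; on this read-out lower numbers stand for an effect already at smaller amounts and higher numbers for an effect only at larger amounts of compound: compound 3 gives 46.8 nM. Its nearest neighbour is compound 2 `COC(=O)C1=C(C)N=C(C)/C(=C(\O)OC)C1c1c(Cl)cccc1Cl`, which in this assay gives 1.91 nM, the step being a 25-fold higher number from compound 2 to compound 3 (1.39 log units; beyond the scatter). The furthest is compound 1 `COC(=O)C1=C(C)N=C(C)/C(=C(\O)OC)C1c1ccc(Cl)cc1`, which gives 8130 nM, separated from compound 3 by a 170-fold lower number from compound 1 to compound 3 (2.24 log units; beyond the scatter).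

The change now considered is 2,3-dichlorophenyl in place of 2-iodophenyl on a saturated ring carbon, giving compound 4 `COC(=O)C1=C(C)N=C(C)/C(=C(\O)OC)C1c1cccc(Cl)c1Cl`.

All three steps bear on it. Each swaps the substituted phenyl ring on the same saturated ring carbon. The step of a 4300-fold lower number from compound 1 to compound 2 (3.63 log units; beyond the scatter) shows that moving from a 4-chlorophenyl to a 2,6-dichlorophenyl brings a very large drop in the number, and a 170-fold lower number from compound 1 to compound 3 (2.24 log units; beyond the scatter) shows a 2-iodophenyl also brings a large drop. The step of a 25-fold higher number from compound 2 to compound 3 (1.39 log units; beyond the scatter) then shows that two chlorines beat one iodine. Compound 4 keeps two chlorines, one of them in the position that the 2,6-dichlorophenyl and 2-iodophenyl share; it is therefore expected to fall between compound 3 and compound 2, with a step of about a 5.9-fold lower number from compound 3 to compound 4 (0.77 log units; beyond the scatter). For compound 4 the estimate in this assay is 8 nM, with a range from 1.5 nM to 40 nM.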

Compound 4, half-maximal effective concentration: 19.1 nM
For compound 4 the middle estimate is 2.4-fold (0.38 log units) below the measured one, within the range that was stated.
By their numbers in this assay, from the lowest: compound 2; then compound 4; then compound 3; then compound 1.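

In this assay, the two dichlorophenyl groups do not behave alike: a 10-fold higher number from compound 2 to compound 4 (1.00 log units; beyond the scatter), so at this saturated ring carbon it matters where the chlorines stand on the phenyl ring, not only that they are there. Replacing the 2-iodophenyl of compound 3 with 2,3-dichlorophenyl changes less, with a 2.5-fold lower number from compound 3 to compound 4 (0.39 log units; beyond the scatter), a modest step, though one beyond the usual scatter. The 2,3-dichlorophenyl group still lies far from the 4-chlorophenyl group, with a 430-fold lower number from compound 1 to compound 4 (2.63 log units; beyond the scatter), so among these four compounds compound 1 remains well apart from compounds 2, 3 and 4, and no measurement at hand gives a reason for any of these differences.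

The compounds shown leave open how a phenyl ring carrying only one of the two chlorines of compound 4 would compare, a comparison that would help separate what each chlorine adds. Also open, on these data alone, is whether a halogen is needed on this ring at all, as a nitro or methoxy group in its place would test, and whether the neighbouring methoxycarbonyl group could give way to an ester with a longer chain.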